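The source may hold more compounds than are shown below. What is called first, only, known or untested is meant among the compounds shown, and "the series" means these compounds.

Measured so far in a functional assay on CCRF-CEM cells (Homo sapiens) for antiproliferative activity, read by cell counting, with a stated time of 2 days; a higher number here means a weaker inhibitor, a lower number a stronger inhibitor
- compound 1 `COc1ccc(Nc2nc(N)c(C(=O)c3ccc(Cl)cc3)s2)cc1` gives 19 nM
- compound 2 `COc1cc(C(=O)c2sc(Nc3ccc(C)cc3)nc2N)cc(OC)c1OC` gives 41 nM

Compound 1 holds the lower number of the two measured compounds, and the gap to compound 2 lies beyond the usual scatter. Compound 3 `COc1ccc(Nc2nc(N)c(C(=O)c3cccc(OC)c3)s2)cc1` has not yet been measured. It keeps the core of compound 1 and carries 3-methoxyphenyl in place of 4-chlorophenyl on a carbonyl carbon. Going by the values given here, no single-place step between measured compounds is available to size this change, so the expectation is loose. Among the compounds with values here, it rests on one comparison: compound 2 (41 nM) is the only other measured compound, and it stands above compound 1. A step to a higher number in this assay, beyond the scatter, is expected, estimated as (a 6.3-fold higher number from compound 1 to compound 3 (0.80 log units; beyond the scatter)). For compound 3 the expected value is (120 nM), with an estimated range of (25 nM) to (600 nM).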

Compound 3, half-maximal inhibitory concentration: 9.9 nM
Compound 3: middle estimate off by 12-fold (1.08 log units), on the high side; measured number outside the range, below it.
By their numbers in this assay, from the lowest: compounds 3 and 1 (each within the scatter of the next); then compound 2.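

In this assay the exchange of 4-chlorophenyl for 3-methoxyphenyl on a carbonyl carbon gives a 1.9-fold lower number from compound 1 to compound 3 (0.28 log units; within the scatter) and so leaves the two groups indistinguishable at this position. Going by these compounds alone, this is the first single-place step, and it shows that the entering group's added hydrogen-bond acceptor and the loss of chlorine produce no readable shift between these two compounds. Nothing measured here bears on why the two groups read alike.

From the compounds shown here alone, how far this holds beyond these two groups remains open, since one step cannot define what the position accepts. A phenyl ring carrying an amine or a carboxylic acid, or a longer chain on the same carbonyl carbon, would show whether the read-out stays level with more distant replacements.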